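The source may hold more compounds than are shown below. What is called first, only, known or untested is meant among the compounds shown, and "the series" means these compounds.

Values so far in an ADME assay on KB cells (Homo sapiens) for cytotoxicity, with a stated time of 48 h (a higher number here means a weaker inhibitor, a lower number a stronger inhibitor), follow:
compound 1 (`CC1=CCC[C@](C)(CC/C(C)=C/CC2=C(O)C(=O)C=C(N[C@H](C(=O)O)[C@@H](C)O)C2=O)[C@@H]1C`) gives > 10 ug/mL as a limit
compound 2 (`C=C1[C@H](C)CCC[C@]1(C)CC/C(C)=C/CC1=C(O)C(=O)C=C(N[C@H](C(=O)O)[C@@H](C)O)C1=O`) gives > 10 ug/mL as a limit
compound 3 (`CC1=CCC[C@](C)(CC/C(C)=C/CC2=C(O)C(=O)C=C(N[C@@H](C(=O)O)C(C)C)C2=O)[C@@H]1C`) gives > 10 ug/mL as a limit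

Compound 2 stands only at a limit, with no number to build on. The series shows the limit of > 10 ug/mL in this assay, at which 3 of the 3 values shown sit, and nothing finer. Compound 4 (`C=C1[C@H](C)CCC[C@]1(C)CC/C(C)=C/CC1=C(O)C(=O)C=C(NCC(=O)O)C1=O`) differs from it thus: hydrogen in place of 1-hydroxyethyl on a saturated chain carbon bound to an amine nitrogen and a carbonyl carbon with 1-carboxy-2-hydroxypropyl becoming carboxymethyl. The closest measured change on the amine nitrogen is a step that the two limits leave unreadable from compound 1 to compound 3 and the other measured change is a step that the two limits leave unreadable from compound 1 to compound 2 and neither gives a size. No step beyond the scatter is therefore expected, and no direction: the estimated move is a step that the limit leaves unreadable from compound 2 to compound 4 in this assay with another limit likely. For compound 4 the expected value is 12 ug/mL with an estimated range of 5 ug/mL to 30 ug/mL overall.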

Compound 4, half-maximal inhibitory concentration: 4 ug/mL
Compound 4: the middle estimate sits 3.0-fold (0.48 log units) above what was measured; measured number outside the range, below it.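

In this assay, going by these compounds alone, hydrogen in place of 1-hydroxyethyl on a saturated chain carbon bound to an amine nitrogen and a carbonyl carbon gives an at least 2.5-fold lower number from compound 2 to compound 4 (0.39 log units; beyond the scatter), the only readable step. The other steps cannot be read, as each joins two limits. Compound 4, at 4 ug/mL, is the only compound shown with a number rather than a limit.

Within the data shown here, whether size at this carbon governs the step stays open, with no compound carrying a lone methyl there. The carboxylic acid also stays unvaried, with no amide in its place.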